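A few compounds are considered here, and "the series" means these few. Any claim that something is new, unique, unknown or untested is made for them only; others in the source may bear on it.

Compound 1, `Cc1cc(Nc2cc(-c3ccccc3)[nH]n2)n2nc(SCc3c(Cl)cccc3Cl)nc2n1`: 5280 nM
Compound 2, `Cc1cc(Nc2cc(-c3ccc(F)cc3)[nH]n2)n2nc(SCc3ccc(Br)cc3)nc2n1`: 2210 nM
Compound 3, `COc1ccc(Cn2ccc(Nc3cc(C)nc4nc(SCc5ccc(Br)cc5)nn34)n2)cc1`: 12600 nM

Of the compounds shown here, three built on the same core have been tested in a functional assay on MGC-803 cells (Homo sapiens) for inhibition, read by MTT assay, with a stated time of 72 h; on this read-out higher numbers stand for weaker inhibition and lower numbers for stronger inhibition. Compound 1 gives 5280 nM, the second highest of the three numbers. Compound 3 sits nearest to it with a higher number, and that gap lies beyond the usual scatter; compound 2 sits furthest with a lower number, and that gap also lies beyond the scatter. No pair among these three differs in a single place, so none of them shows how one change alone moves the number.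

The next compound, compound 4, is `Cc1cc(Nc2cc(-c3ccccc3)[nH]n2)n2nc(SCC(=O)c3ccccc3)nc2n1`. It differs from compound 1 in one place: benzoyl in place of 2,6-dichlorophenyl on a saturated chain carbon bound to a sulfur. Nothing measured here tells how this kind of swap on a saturated chain carbon bound to a sulfur affects this assay, so the expectation rests on compound 1 alone, with a wide range. The step of a 1.1-fold higher number from compound 1 to compound 4 (0.06 log units; within the scatter) is expected to be small, either direction, and within the scatter. Compound 4 is estimated to give 6000 nM in this assay, between 2000 nM and 18000 nM.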

Compound 4, half-maximal inhibitory concentration: 2580 nM
Compound 4: the middle estimate sits 2.3-fold (0.37 log units) above what was measured; the measured number falls inside the stated range.
By their numbers in this assay, from the lowest: compounds 2 and 4 (each within the scatter of the next); then compound 1; then compound 3.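

In this assay, for the compounds shown here, the first comparison that changes only one place gives a 2.0-fold lower number from compound 1 to compound 4 (0.31 log units; beyond the scatter) when benzoyl replaces 2,6-dichlorophenyl on a saturated chain carbon bound to a sulfur, a modest step that lies beyond the scatter. It shows that this position responds to a change of group and that the chlorine-bearing ring can be exchanged for a ring joined through a carbonyl without a higher number in this pair. No supporting measurement accounts for the shift.

This single step removes the chlorine atoms and adds the carbonyl together, so it cannot show how much each contributes. From the compounds shown here alone, whether a carboxylic acid, an amine or a longer chain at this carbon would lower the number further remains open.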